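Chain-terminal piperazine extension of the benzamide series

The source may report more compounds than this note shows. Statements on the series, on what has been measured and on what is new or still open speak of the compounds shown alone.

Compound 2 `CCCCCN1CCC(NC(=O)c2cc(Cl)c(N)cc2OC)CC1` gives 25.1 nM in a functional assay on HEK293 cells for agonist activity at 5-hydroxytryptamine receptor 4 (Homo sapiens), read by cAMP accumulation; a lower number here means that less compound is needed, a higher number that more compound is needed for the effect. Among the measured compounds shown here, of the two numbers available in this assay it is the lowest; the only other measured compound, compound 1 `CC(C)n1c(=O)n(C(=O)NC2CCNCC2)c2ccccc21`, gives 316 nM in this assay, a gap that lies beyond the usual scatter, although compounds 1 and 2 share no single-point change and nothing further can be read from that pair.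

Compound 3 `COc1cc(N)c(Cl)cc1C(=O)NC1CCN(CCCCCN2CCN(S(C)(=O)=O)CC2)CC1` has not yet been run in this assay. Relative to compound 2 the change is 4-(methylsulfonyl)piperazin-1-yl in place of hydrogen on a saturated chain carbon, five bonds along the chain from an amine nitrogen in a ring. The amide, the substituted aromatic ring and the ring amine of compound 2 are kept; only the end of the five-carbon chain is altered.

For the measured compounds named here, no measured step of comparable kind is available, so the direction of the step is uncertain. Working from the value of compound 2 in this assay, 25.1 nM, compound 3 is expected to stay close to it, with a step of a 2.1-fold lower number from compound 2 to compound 3 (0.32 log units; beyond the scatter) that may be no more than the scatter or a modest move to a lower number. The estimate for compound 3 in this assay is therefore 12 nM, with a range from 2.5 nM to 60 nM.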

Compound 3, half-maximal effective concentration: 12.6 nM
Beside the measured number, compound 3's estimate is 1.1-fold (0.02 log units) below it, and the stated range covers the measured number.
By their numbers in this assay, from the lowest: compounds 3 and 2 (each within the scatter of the next); then compound 1.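

In this assay, among the compounds shown here, the first readable single-point step in this set is a 2.0-fold lower number from compound 2 to compound 3 (0.30 log units; within the scatter) and it comes from placing 4-(methylsulfonyl)piperazin-1-yl on a saturated chain carbon, five bonds along the chain from an amine nitrogen in a ring. This position therefore accepts an addition of 10 heavy atoms, including a six-membered non-aromatic ring, with the two compounds remaining indistinguishable in this read-out, something that the pair of compound 1 and compound 2 could not show because they share no single-point change. No accompanying measurement bears on how this outcome arises.

The compounds shown leave open whether the methylsulfonyl group or the piperazine ring matters at the chain end, a question that an unsubstituted piperazine, an acetyl in place of methylsulfonyl, or a simple terminal amine or carboxylic acid would address. Also open, going by these compounds, is how far this tolerance depends on chain length, which a shorter or longer chain bearing the same 4-(methylsulfonyl)piperazin-1-yl group would test.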